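The source may report more compounds than this note shows. Statements on the series, on what has been measured and on what is new or still open speak of the compounds shown alone.

Measured so far:
compound 1 `CCCCCCCCCCc1ccc(-c2noc(CCCCN)n2)cc1` — 55%
compound 2 `CCCCCCCCCCc1ccc(-c2noc([C@@H]3CCCN3)n2)cc1` — 21%
compound 3 `CCCCCCCCCCc1ccc(-c2noc(C3CCNCC3)n2)cc1` — 66%

In an assay on HeLa cells for inhibition of sphingosine-1-phosphate transporter SPNS2 (Mus musculus), read by LC-MS, tested at 2 uM (on this read-out higher numbers stand for more inhibition at the one concentration tested (going by the name of the read-out) and lower numbers for less inhibition), compound 1 stands second highest of the three numbers. Compound 3 is nearest, a number 11 percentage points higher from compound 1 to compound 3 (beyond the scatter); compound 2 is furthest, a number 34 percentage points lower from compound 1 to compound 2 (beyond the scatter). The step of a number 45 percentage points higher from compound 2 to compound 3 (beyond the scatter) shows the same ordering of the two ring-bearing amines.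

Compound 4 `CCCCCCCCCCc1ccc(-c2noc([C@@H]3CCC[C@@H](N)C3)n2)cc1` is to be measured in this assay. It differs from compound 1 as follows: 3-aminocyclohexyl in place of 4-aminobutyl on an aromatic carbon.

The bearing steps are the two in which the 4-aminobutyl of compound 1 is exchanged for an amine carried on a non-aromatic ring: the modest rise to compound 3 and the large fall to compound 2. Going by the values given here, the entering 3-aminocyclohexyl, a six-membered ring with the nitrogen outside it, has no direct counterpart among the measured compounds, so the precedent points both ways. The expected step from compound 1 is a number 3 percentage points higher from compound 1 to compound 4 (within the scatter), with a wide range.

For compound 4 the estimate in this assay is 58%, expected between 35% and 78%.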

Compound 4, a percentage reported as inhibition, at one concentration (the size of the read-out at that concentration, not a potency): 13%
The estimate for compound 4 lay 45 percentage points above the measured number, and the stated range ends above it.
By their numbers in this assay, from the lowest: compounds 4 and 2 (each within the scatter of the next); then compound 1; then compound 3.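

In this assay the step of a number 42 percentage points lower from compound 1 to compound 4 (beyond the scatter) shows that a six-membered ring at this position does not by itself hold inhibition at the level of compound 1. The step of a number 53 percentage points lower from compound 3 to compound 4 (beyond the scatter) separates two six-membered rings that each carry an amine, so the number for compound 3 belongs to piperidin-4-yl and not to ring size alone. With the step of a number 8 percentage points lower from compound 2 to compound 4 (within the scatter) between them, 3-aminocyclohexyl and pyrrolidin-2-yl both sit at the low end of these compounds, and piperidin-4-yl remains the only ring here that stands above 4-aminobutyl.

Open, as far as these compounds go, are how piperidin-3-yl or a carboxylic acid in place of the amine would stand at this position, and whether another stereoisomer of 3-aminocyclohexyl would read differently. Nothing available here bears on the reason for this drop.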